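The compounds below may be only part of what the source reports. "The series", "measured", "known", "first", "only" and "open" are said of these compounds alone.

Compound 2 `CCCc1nc(N2CCN(c3ccccc3OC)CC2)c2cc(OC)c(OC)cc2n1` is known only as a limit: in an in vitro assay on U2OS cells for agonist activity at neurotensin receptor type 2 (Homo sapiens), read by reporter gene assay and beta-arrestin recruitment (a higher number here means that more compound is needed for the effect, a lower number that less compound is needed), compound 2 gives > 80000 nM. Compound 1 `COc1cc2ncnc(N3CCN(c4ccccc4OC)CC3)c2cc1OC` also gives only a limit, > 80000 nM, in this assay. The step that the two limits leave unreadable from compound 1 to compound 2 is therefore not readable. Compound 3 `COc1cc2nc(CC3CC3)nc(N3CCN(c4ccccc4OC)CC3)c2cc1OC` carries cyclopropyl in place of ethyl on a saturated chain carbon bound to an aromatic carbon. Within the data shown here, no measured step bears on this change; the only guide is the limit of > 80000 nM in this assay, at which 2 of the 2 values shown sit. For compound 3 the expectation is a result at or near the same limit, an expected step that the limit leaves unreadable from compound 2 to compound 3. The estimate for compound 3 is 100000 nM, with an expected range from 30000 nM to 400000 nM.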

Compound 3, half-maximal effective concentration: > 80000 nM
Compound 3 gave a limit, no number (the forecaster's own chance of this, stated with the estimate: 85%); the middle value is on the limit's open side.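

Compound 2 and compound 3, like compound 1, remain limits and not numbers, so no step among them can be read: the limit of > 80000 nM in this assay, at which 3 of the 3 values shown sit.

The compounds shown leave open whether any group at this place gives a readable value in this assay.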